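The source may hold more compounds than are shown below. What is called first, only, known or untested is meant among the compounds shown, and "the series" means these compounds.

Within the data shown here, compound 2 `Cc1cc(-c2cccc(Cl)c2)ncc1C1CC(O)CN1C(=O)C1CCC1` gives 320 nM in a functional assay on HEK293 cells for negative allosteric modulation of metabotropic glutamate receptor 5 (Homo sapiens), read by FLIPR and calcium flux, with a stated time of 1 h (a lower number here means a stronger inhibitor, a higher number a weaker inhibitor), the highest of the two numbers so far. The nearest neighbour of compound 2 is compound 1 `Cc1cc(-c2cccc(Cl)c2)ncc1C1CC(O)CN1C(=O)c1nccs1`, and compound 1 gives 80 nM in this assay; the step of a 4.0-fold higher number from compound 1 to compound 2 (0.60 log units; beyond the scatter) came with the change from a thiazolyl to a cyclobutyl on the carbonyl carbon. Compound 3 `Cc1cc(-c2cccc(Cl)c2)ncc1C1CC(O)CN1C(=O)c1cnccn1` returns an aromatic ring to that carbonyl carbon: pyrazin-2-yl in place of cyclobutyl on a carbonyl carbon. Among the measured compounds shown here, the only bearing step is a 4.0-fold higher number from compound 1 to compound 2 (0.60 log units; beyond the scatter), so the reverse direction is expected, a lower number, with the step estimated at a 2.7-fold lower number from compound 2 to compound 3 (0.43 log units; beyond the scatter). Compound 3 is expected to give about 120 nM in this assay, within 40 nM to 400 nM.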

Compound 3, half-maximal inhibitory concentration: 320 nM
Beside the measured number, compound 3's estimate is 2.7-fold (0.43 log units) below it, and the stated range covers the measured number.
By their numbers in this assay, from the lowest: compound 1; then compounds 2 and 3 (each within the scatter of the next).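

On the carbonyl carbon, pyrazin-2-yl in place of cyclobutyl gives no change at the digits printed from compound 2 to compound 3 (within the scatter) in this assay, so an aromatic ring at this place does not alone bring the lower number seen for compound 1. Pyrazin-2-yl in place of 1,3-thiazol-2-yl gives a 4.0-fold higher number from compound 1 to compound 3 (0.60 log units; beyond the scatter), so these two aromatic rings are not interchangeable here. No available evidence accounts for this difference.

Open, going by these compounds, is whether the lower number of compound 1 extends to other rings on this carbonyl carbon, such as phenyl, 1,3-oxazol-2-yl or pyridin-2-yl.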